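The compounds below may be only part of what the source reports. "The series", "measured", "known", "first", "only" and "open" are said of these compounds alone.

Measured in a functional assay for inhibition, with Rattus norvegicus as the target; a lower number here means a stronger inhibitor, a higher number a weaker inhibitor:
- Compound 1 `CSc1ccc(Nc2c(NC(C)C(C)(C)C)c(=O)c2=O)cc1`: > 30000 nM, a limit of the assay and not a number
- Compound 2 `Cc1cc(C#N)ccc1/N=c1\c(O)c(O)\c1=N/[C@H](C)C(C)(C)C`: 1080 nM

Within the data shown here, compound 2 holds the only actual number so far, and the sole other entry is a limit. Compound 3 `C[C@@H](/N=c1\c(O)c(O)\c1=N/c1ccc(C#N)cc1O)C(C)(C)C` changes one group of compound 2: hydroxy in place of methyl on an aromatic carbon. This puts hydroxy in place of methyl on an aromatic carbon, ortho to a large group and meta to a cyano group. Among the measured compounds shown here, no measured pair isolates this change, so there is no direct precedent for its size. For the measured compounds named here, the only anchor is compound 2 at 1080 nM. A moderate weakening in this assay is expected, although a gain cannot be excluded. The expected move is a 2.3-fold higher number from compound 2 to compound 3 (0.36 log units; beyond the scatter). Compound 3 is estimated at 2500 nM, with an expected range of 400 nM to 15000 nM.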

Compound 3, half-maximal inhibitory concentration: 6050 nM
The estimate for compound 3 lay 2.4-fold (0.38 log units) below the measured number, within the range that was stated.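

In this assay, hydroxy in place of methyl on an aromatic carbon, ortho to a large group and meta to a cyano group, gives a 5.6-fold higher number from compound 2 to compound 3 (0.75 log units; beyond the scatter), the first size available for a change at this place. Compound 3 still gives a number, 6050 nM, so this place accepts hydroxy with a read-out that can be measured. This single step cannot separate the loss of methyl from the arrival of hydroxy, with its added hydrogen-bond donor and acceptor.

Compound 1 holds a limit of the assay and not a number, and it differs from the others in more than one place: the limit of > 30000 nM in this assay, at which 1 of the 3 values shown sits. On these data alone, whether methoxy, fluorine or an amine at this carbon would fall nearer compound 2 or compound 3 stays open, as does whether this step keeps its direction with another group in place of cyano.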